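This account rests on a few compounds, and the source may have more. Where it says the series, first, only, none or still open, it means among the compounds named here.

Among the measured compounds shown here, in an ADME assay on cells (Hepatocyte, Homo sapiens) for metabolic stability, read by LC-MS, with a stated time of 3 h, tested at 1 uM (on this read-out lower numbers stand for slow clearance and higher numbers for fast clearance), compound 2 `CS(=O)(=O)NC(=O)c1cc(C2CC2)c(OCC2CCN(C(=O)c3cc(Cl)cc(Cl)c3)CC2)cc1F` gives 7.5 mL/min/kg, the only true number available so far. Compound 1 `CC(C)(c1cc(Cl)cc(Cl)c1)N1CCC(COc2cc(F)c(C(=O)NS(C)(=O)=O)cc2C2CC2)CC1` gives < 6.2 mL/min/kg, which is a limit of the assay and not a number. Compound 3 `CS(=O)(=O)NC(=O)c1cc(C2CC2)c(OCC2CCN(Cc3ccc(Cl)cc3)CC2)cc1F` differs from compound 2 in one place: 4-chlorobenzyl in place of (3,5-dichlorophenyl)carbonyl on an amine nitrogen in a ring. There, 4-chlorobenzyl stands in place of (3,5-dichlorophenyl)carbonyl on an amine nitrogen in a ring. For the measured compounds named here, only one measured step bears on this change, as it alters the group on that same nitrogen: an at least 1.2-fold higher number from compound 1 to compound 2 (0.08 log units; that floor lies within the scatter). Its size is known only as a floor, set by the limit of < 6.2 mL/min/kg in this assay, at which 1 of the 2 values shown sits, and that floor does not leave the scatter. It therefore gives no firm sign of how strongly this position moves clearance, and the entering group matches neither group in that step. With so little to go on, no change beyond the scatter is expected, though a slight rise is allowed for, and the expected step is a 1.2-fold higher number from compound 2 to compound 3 (0.08 log units; within the scatter). For compound 3 the estimated clearance is 9 mL/min/kg, with an expected range from 4.5 mL/min/kg to 18 mL/min/kg.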

Compound 3, clearance: 15 mL/min/kg
Beside the measured number, compound 3's estimate is 1.7-fold (0.22 log units) below it, and the stated range covers the measured number.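

In this assay, putting 4-chlorobenzyl in place of (3,5-dichlorophenyl)carbonyl on the amine nitrogen gives a 2.0-fold higher number from compound 2 to compound 3 (0.30 log units; within the scatter), so this change does not separate compound 2 from compound 3 beyond the usual scatter of repeated measurements. Among the compounds shown here, the group on this nitrogen can still matter for clearance, since exchanging 1-(3,5-dichlorophenyl)-1-methylethyl for 4-chlorobenzyl gives an at least 2.4-fold higher number from compound 1 to compound 3 (0.38 log units; beyond the scatter), and this is the first step at this position to leave the scatter. Compound 1 stands at a limit of the assay and not at a number, so the size of that step is known only as a floor: the limit of < 6.2 mL/min/kg in this assay, at which 1 of the 3 values shown sits.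

The 4-chlorobenzyl group differs from 1-(3,5-dichlorophenyl)-1-methylethyl both in its chlorine atoms and in the two methyl groups on the carbon attached to the nitrogen, and the compounds shown do not tell which of these parts goes with the step. From the compounds shown here alone, it also remains open how clearance would read with a 3,5-dichlorobenzyl group or a 4-chlorobenzoyl group on the same nitrogen, either of which would take the chlorine pattern and the carbonyl one at a time.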